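Compound 3 to compound 4: a 4-fluorophenyl exchange

The source may hold more compounds than are shown below. What is called first, only, known or untested is meant among the compounds shown, and "the series" means these compounds.

Values so far in a physicochemical assay for solubility; a higher number here means a more soluble compound, a lower number a less soluble compound
- compound 1 `CN1CCN(c2cc(C(F)(F)F)ccc2[C@H]2CCOc3cc(S(=O)(=O)Nc4nccs4)ccc32)CC1` gives 176000 nM
- compound 2 `O=S(=O)(Nc1nccs1)c1ccc2c(c1)OCC[C@H]2c1ccc(C(F)(F)F)cc1-c1nccs1` gives 7000 nM
- compound 3 `O=C1OCCN1c1cc(C(F)(F)F)ccc1[C@H]1CCOc2cc(S(=O)(=O)Nc3nccs3)ccc21` gives 295000 nM

Compound 3 at 295000 nM lies within the scatter of compound 1 at 176000 nM. Compound 2 stands at 7000 nM on the same read-out. The gap between compound 3 and compound 2 lies well beyond the scatter.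

The next structure is compound 4 `O=S(=O)(Nc1nccs1)c1ccc2c(c1)OCC[C@@H]2c1ccc(C(F)(F)F)cc1-c1ccc(F)cc1` and the change is 4-fluorophenyl in place of 2-oxo-1,3-oxazolidin-3-yl on an aromatic carbon in a place described as ortho to a large group and meta to a trifluoromethyl group.

For the measured compounds named here, only one measured step concerns this place directly. It is a 1.7-fold higher number from compound 1 to compound 3 (0.22 log units; within the scatter) and it stays within the scatter, but 4-fluorophenyl takes no part in it, so it does not cover the present change. Going by the values given here, compound 2 also differs from compound 3 at this place, and compound 2 at 7000 nM is the only value well apart from the others. That single comparison is thin support, yet a clear drop in this assay beyond the scatter is expected, closer to the level of compound 2 than to that of compound 3.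

The expected size of the change is a 49-fold lower number from compound 3 to compound 4 (1.69 log units; beyond the scatter) as an estimate. Compound 4 is expected at 6000 nM with an estimated range of 1500 nM to 25000 nM for now.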

Compound 4, solubility: 39000 nM
Compound 4: the middle estimate sits 6.5-fold (0.81 log units) below what was measured; measured number above the stated range.
By their numbers in this assay, from the lowest: compound 2; then compound 4; then compounds 1 and 3 (each within the scatter of the next).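

In this assay, this place, ortho to a large group and meta to a trifluoromethyl group, now gives steps beyond the scatter: a 7.6-fold lower number from compound 3 to compound 4 (0.88 log units; beyond the scatter) with 4-fluorophenyl in place of 2-oxo-1,3-oxazolidin-3-yl, and a 4.5-fold lower number from compound 1 to compound 4 (0.65 log units; beyond the scatter) with 4-fluorophenyl in place of 4-methylpiperazin-1-yl. For the compounds shown here, the only earlier step at this place stayed within the scatter, so the two non-aromatic rings could not be told apart, whereas 4-fluorophenyl separates from both, though each step is modest. The printed values also show compound 4 at 39000 nM still well above compound 2 at 7000 nM and so place it between the other compounds, which means an aromatic ring here does not by itself fix the number at the level of compound 2. No measurement in hand accounts for the fall seen with this exchange.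

The compounds shown leave open where an unsubstituted phenyl, an open-chain amine or a carboxylic acid at this place would stand in this assay. They also leave open whether the same order of groups at this place would hold on a core changed elsewhere.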